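Hydroxy for Chloro in a Cell Viability Test

The source may report more compounds than this note shows. Statements on the series, on what has been measured and on what is new or still open speak of the compounds shown alone.

Measured compounds:
compound 2 `O=C1CSC(c2cccc(Cl)c2)N1CCN1CCCCC1` gives 100%
compound 1 `COc1ccc(C2SCC(=O)N2CCN2CCCCC2)cc1` gives 89%

Both were run in an ADME assay on Vero cells (Chlorocebus sabaeus) for cytotoxicity, read by neutral red uptake, tested at 98 ug/mL; a lower number here means a stronger effect, a higher number a weaker effect of the compound at the concentration tested. Compound 2 stands highest of the two numbers, and compound 1 sits lower by a gap beyond the usual scatter. Compound 3 `O=C1CSC(c2cccc(O)c2)N1CCN1CCCCC1` has not been measured. It differs from compound 2 by hydroxy in place of chloro on an aromatic carbon. Going by the values given here, no measured pair shows this change, so the expected step in this assay is small, probably none beyond the scatter. For compound 3 the estimated value is 95%, from 80% to 105%. The expected step of a number 5 percentage points lower from compound 2 to compound 3 (within the scatter) is accordingly small.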

Compound 3, a percentage reported as activity, at one concentration (the size of the read-out at that concentration, not a potency): 100%
Estimate against measurement, compound 3: 5 percentage points below, within the range that was stated.
By their numbers in this assay, from the lowest: compound 1; then compounds 2 and 3 (each within the scatter of the next).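

In this assay, putting hydroxy in place of chloro on this aromatic carbon gives no change at the digits printed from compound 2 to compound 3 (within the scatter). Going by these compounds alone, this single pair offers the first direct comparison at this position: going from 3-chlorophenyl to 3-hydroxyphenyl adds a hydrogen-bond donor and acceptor without a step that can be told from the scatter. No measurement shown explains this result.

The compounds shown leave open whether an amine or a carboxylic acid at this position would read the same way. One pair also cannot show whether this swap would give the same result on a different core.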